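From 4-bromophenyl to 2,3-dichlorophenyl in a cell assay

The compounds below may be only part of what the source reports. "The series", "measured", "known", "first", "only" and "open" are said of these compounds alone.

In a functional assay on SW-620 cells (Homo sapiens) for cytotoxicity, read by MTT assay, with a stated time of 72 h (a lower number here means a stronger inhibitor, a higher number a weaker inhibitor), compound 1 (`COc1ccc(/C=C2\CCC/C(=C\c3cccc(OC)c3OC)C2=O)cc1`) gives 13600 nM while compound 2 (`COc1cc(/C=C2\CCC/C(=C\c3cccc(OC)c3OC)C2=O)cc(OC)c1`) gives 3800 nM and compound 3 (`COc1ccc(/C=C2\CCC/C(=C\c3ccc(Br)cc3)C2=O)cc1OC`) gives 5200 nM on the same scale. Compound 3 and compound 2 lie within the usual scatter of each other, so they cannot be told apart. Compound 1 has a higher number than compound 3, beyond the scatter, which makes it the weaker of that pair.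

Compound 4 (`COc1ccc(/C=C2\CCC/C(=C\c3cccc(Cl)c3Cl)C2=O)cc1OC`) has not been measured yet. It carries 2,3-dichlorophenyl in place of 4-bromophenyl on a double-bonded chain carbon bound to a double-bonded ring carbon. Among the measured compounds shown here, no two measured compounds differ in one place only, so nothing here shows directly what this swap does, and the expectation starts from compound 3 at 5200 nM as its anchor. The expected step of a 1.0-fold lower number from compound 3 to compound 4 (0.02 log units; within the scatter) in this assay is small and is not expected to go beyond the scatter in either direction. For compound 4 the estimated value is 5000 nM with an expected range from 2000 nM to 12000 nM in this measurement.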

Compound 4, half-maximal inhibitory concentration: 10800 nM
Beside the measured number, compound 4's estimate is 2.2-fold (0.33 log units) below it; the range from low to high includes it.
By their numbers in this assay, from the lowest: compounds 2 and 3 (each within the scatter of the next); then compounds 4 and 1 (each within the scatter of the next).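

Among the compounds shown here, this is the first pair here that differs in one place only, so the group on a double-bonded chain carbon bound to a double-bonded ring carbon can now be judged directly. In this assay, placing 2,3-dichlorophenyl where 4-bromophenyl stood gives a 2.1-fold higher number from compound 3 to compound 4 (0.32 log units; beyond the scatter) and so a weaker compound, a modest step but one beyond the scatter. The choice of halogen-bearing phenyl at this place therefore matters in this cell assay, although no measurement shown explains the loss.

This single swap changes the halogen, the number of halogens and where they sit on the phenyl ring all at once, so it cannot say which of these changes matters. Also open, going by these compounds, is how this position would respond to an unsubstituted phenyl, a phenyl carrying one chlorine, or a phenyl carrying an amine or a carboxylic acid.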